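Cyano to Carbamoyl: Does a Small Swap Repeat?

This account rests on a few compounds, and the source may have more. Where it says the series, first, only, none or still open, it means among the compounds named here.

Of the compounds shown here, three have been tested in an assay on isolated protein for inhibition of 2-Hydroxyacid oxidase 2 (Homo sapiens), tested at 1 uM; on this read-out higher numbers stand for a stronger effect at the one concentration tested and lower numbers for a weaker effect. Compound 1 `Cc1n[nH]c(C(=O)O)c1Cc1cccc(-c2ccc(C#N)cc2)c1` gives 13%, and compound 2 `Cc1n[nH]c(C(=O)O)c1Cc1cccc(-c2ccc(C(N)=O)cc2)c1` gives 18%. For the measured compounds named here, the difference between these two is carbamoyl in place of cyano on an aromatic carbon, and the step of a number 5 percentage points higher from compound 1 to compound 2 (within the scatter) is the only measured example of that change. Compound 3 `Cc1n[nH]c(C(=O)O)c1Cc1ccc(C#N)cc1` gives 0% in this assay, the lowest of the three numbers, and the difference between the core of compound 3 and the core of compound 1 is not broken down here.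

Compound 4 `Cc1n[nH]c(C(=O)O)c1Cc1ccc(C(N)=O)cc1` has not yet been measured. It differs from compound 3 by carbamoyl in place of cyano on an aromatic carbon, which is the same change that separates compound 2 from compound 1, at the same kind of place. Going by the values given here, because a number 5 percentage points higher from compound 1 to compound 2 (within the scatter) stayed within the scatter, the step from compound 3 to compound 4 is expected to be of similar small size, a number 3 percentage points higher from compound 3 to compound 4 (within the scatter), on the single precedent available. Compound 4 is therefore estimated to give about 3% in this assay, most likely between -5% and 12%.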

Compound 4, a percentage reported as inhibition, at one concentration (the size of the read-out at that concentration, not a potency): 0%
The estimate for compound 4 lay 3 percentage points above the measured number; the range from low to high includes it.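

In this assay, putting carbamoyl in place of cyano on the second core gives no change at the digits printed from compound 3 to compound 4 (within the scatter). Set beside the first example, the change carries over from one core to the other without a detectable difference: the same change on two cores in this assay, a number 5 percentage points higher (within the scatter) from compound 1 to compound 2 and no change at the digits printed (within the scatter) from compound 3 to compound 4, 5 percentage points apart, within the scatter of two such steps. For the compounds shown here, this shows only that the swap left the read-out within the scatter on both cores; it does not show that carbamoyl and cyano are equivalent in general, and two weakly active pairs tested at a single concentration cannot predict the result on a third core.

The compounds shown leave open whether this change would stay just as small on a core with a much stronger effect, where a real difference would be easier to see. They also leave open whether another group on the same aromatic carbon, such as an amine or a sulfonamide, would move the read-out beyond the scatter on either core.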